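Cytotoxicity notes: piperazine variants on the shared core

A few compounds are considered here, and "the series" means these few. Any claim that something is new, unique, unknown or untested is made for them only; others in the source may bear on it.

Measured in an ADME assay on MT4 cells (Homo sapiens) for cytotoxicity, read by MTT assay, with a stated time of 5 days; a lower number here means that less compound is tolerated, a higher number that more compound is tolerated:
compound 1 `Cc1cc(/C=C/C#N)cc(C)c1Oc1nc(Nc2ccc(N3CCCC(NS(N)(=O)=O)C3)cc2)nc2ccsc12`: > 217000 nM (a limit of the assay)
compound 2 `Cc1cc(/C=C/C#N)cc(C)c1Oc1nc(Nc2ccc(CN3CCNCC3)cc2)nc2ccsc12`: 3970 nM
compound 3 `Cc1cc(/C=C/C#N)cc(C)c1Oc1nc(Nc2ccc(CN3CCN(S(C)(=O)=O)CC3)cc2)nc2sccc12`: 131000 nM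

Compound 3 holds the highest of the two numbers in this assay; the nearest number, that of compound 2, is lower and the gap is beyond the scatter. For compound 1 the assay reports only a limit, (the limit of > 217000 nM in this assay, at which 1 of the 3 values shown sits).

Compound 4 `Cc1cc(/C=C/C#N)cc(C)c1Oc1nc(Nc2ccc(N3CCNCC3)cc2)nc2sccc12` has not been measured in this assay. It differs from compound 3 in one place: piperazin-1-yl in place of (4-(methylsulfonyl)piperazin-1-yl)methyl on an aromatic carbon.

Going by the values given here, the only measured step in this assay that bears on this change is an at least 54-fold lower number from compound 1 to compound 2 (1.73 log units; beyond the scatter): there too a sulfonyl-bearing substituent gave way to a free piperazine on the same aromatic carbon, and the number fell by a large amount. Compound 2, which carries the free piperazine through a methylene, sits at 3970 nM. The step of a 26-fold lower number from compound 3 to compound 4 (1.42 log units; beyond the scatter) is therefore expected to be downward and large, landing compound 4 close to that figure. Compound 4 is estimated at 5000 nM, with a range from 1500 nM to 20000 nM.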

Compound 4, half-maximal cytotoxic concentration: 4740 nM
For compound 4 the middle estimate is 1.1-fold (0.02 log units) above the measured one, and the stated range covers the measured number.
By their numbers in this assay, from the lowest: compounds 2 and 4 (each within the scatter of the next); then compound 3. At a limit, above all of these: compound 1.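

In this assay the change gives a 28-fold lower number from compound 3 to compound 4 (1.44 log units; beyond the scatter) on this aromatic carbon, para to a large group, and this step has a measured number at both ends. Compound 1 stands only at a limit, > 217000 nM, so the earlier step at this carbon had no fixed size. The fall here comes with a smaller substituent and with a hydrogen-bond donor where the leaving group has none, but nothing shown gives a cause for it.

On these data alone, the step removes the methylsulfonyl and the methylene linker together, so the share of each in the fall stays open. Also open, as far as these compounds go, is where an acetyl or a plain methyl on the piperazine nitrogen would place the number on this core.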